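The compounds below may be only part of what the source reports. "The series", "measured", "known", "first", "only" and "open" are said of these compounds alone.

Measured so far in a functional assay on RS4-11 cells (Homo sapiens) for inhibition, read by CCK-8 assay, with a stated time of 48 h, tested at 20 uM; a lower number here means less inhibition of growth, a higher number more inhibition of growth at the concentration tested:
compound 1 `COc1ccc(Cc2nnc(NC(=O)/C(C#N)=C/c3ccccc3OS(=O)(=O)c3ccc(F)cc3)s2)cc1`: 80%
compound 2 `Cc1ccc(Cc2nnc(NC(=O)/C(C#N)=C/c3ccccc3OS(=O)(=O)c3ccc(Cl)cc3)s2)cc1`: 72%

Compound 2 and compound 1 lie within the scatter of each other, so these numbers do not rank them. Compound 3 `Cc1ccc(Cc2nnc(NC(=O)/C(C#N)=C/c3ccccc3OS(=O)(=O)c3ccc(F)cc3)s2)cc1` comes from compound 2 by one small change: fluoro in place of chloro on an aromatic carbon. This places fluoro in place of chloro on an aromatic carbon, para to a large group. Among the measured compounds shown here, no measured pair shows this change alone. For the measured compounds named here, the only guide is that compound 2 at 72% and compound 1 at 80% sit close together. The expected a number 3 percentage points higher from compound 2 to compound 3 (within the scatter) stays within the scatter, with no firm direction. The estimated value for compound 3 is 75%, with an expected range of 63% to 87%.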

Compound 3, percent growth inhibition at one concentration: 73%
Beside the measured number, compound 3's estimate is 2 percentage points above it; measured number inside the range.
By their numbers in this assay, from the lowest: compounds 2, 3 and 1 (each within the scatter of the next).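

In this assay, fluoro in place of chloro on an aromatic carbon, para to a large group, gives a number 1 percentage points higher from compound 2 to compound 3 (within the scatter), so this pair does not separate the two halogens at this position. Methyl in place of methoxy on an aromatic carbon gives a number 7 percentage points lower from compound 1 to compound 3 (within the scatter), so that single change does not separate its pair either. No measurement here offers an explanation for these results.

From the compounds shown here alone, whether an amine or a carboxylic acid in place of the halogen on this ring would shift growth inhibition beyond the scatter remains open.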